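Cyclopentyl ester in place of tert-butyl ester

The compounds below may be only part of what the source reports. "The series", "measured", "known", "first", "only" and "open" are said of these compounds alone.

Three dihydropyridine esters were compared in an assay on isolated protein for antagonist activity at Voltage-dependent L-type calcium channel subunit alpha-1C (Cavia porcellus), with a stated time of 15 min; on this read-out lower numbers stand for stronger inhibition and higher numbers for weaker inhibition. Compound 1 `CCOC(=O)C1=C(C)NC(C)=C(C(=O)OC)C1c1csc(-c2ccc(Cl)cc2)n1` gives 22000 nM, compound 2 `CCCOC(=O)C1=C(C)NC(C)=C(C(=O)OCC)C1c1csc(-c2ccc(Cl)cc2)n1` gives 4090 nM, and compound 3 `CCOC(=O)C1=C(C)NC(C)=C(C(=O)OC(C)(C)C)C1c1csc(-c2ccc(Cl)cc2)n1` gives 91000 nM. Compound 3 therefore has the highest number of the three: the step of a 4.1-fold higher number from compound 1 to compound 3 (0.62 log units; beyond the scatter) and the step of a 22-fold higher number from compound 2 to compound 3 (1.35 log units; beyond the scatter) both run toward weaker inhibition, while the step of a 5.4-fold lower number from compound 1 to compound 2 (0.73 log units; beyond the scatter) shows that lengthening the chain on the other ester goes the opposite way.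

Compound 4 `CCOC(=O)C1=C(C)NC(C)=C(C(=O)OC2CCCC2)C1c1csc(-c2ccc(Cl)cc2)n1` differs from compound 3 by cyclopentyl in place of tert-butyl on an oxygen next to a carbonyl group. The measured steps that bear on this are the two that lead into compound 3 and both show that the tert-butyl group is the weakest ester substituent seen so far. Within the data shown here, compound 4 is therefore expected to give a lower number than compound 3 in this assay, with the step of a 4.6-fold lower number from compound 3 to compound 4 (0.66 log units; beyond the scatter) estimated as modest, since no measured step shows a cyclopentyl group directly. The estimate for compound 4 in this assay is 20000 nM, expected within 5000 nM to 80000 nM.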

Compound 4, half-maximal inhibitory concentration: 8380 nM
Compound 4: middle estimate off by 2.4-fold (0.38 log units), on the high side; measured number inside the range.
By their numbers in this assay, from the lowest: compound 2; then compound 4; then compound 1; then compound 3.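

With cyclopentyl in place of tert-butyl on the oxygen, this assay shows an 11-fold lower number from compound 3 to compound 4 (1.04 log units; beyond the scatter), so the high number of compound 3 does not carry over to every larger carbon group at this place. The cyclopentyl ester also sits among the earlier esters, with a 2.6-fold lower number from compound 1 to compound 4 (0.42 log units; beyond the scatter) on one side and a 2.0-fold higher number from compound 2 to compound 4 (0.31 log units; beyond the scatter) on the other, which shows that a ring here is compatible with a number in the range of the open-chain esters. Nothing measured here accounts for the gap between tert-butyl and cyclopentyl.

On these data alone, how isopropyl, cyclopropyl or cyclohexyl on this oxygen would compare remains open. So does whether a longer chain ending in an amine or a carboxylic acid would keep or lose the inhibition seen with cyclopentyl.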